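Amide-linked amine variation on two chromene benzophenone cores

A few compounds are considered here, and "the series" means these few. Any claim that something is new, unique, unknown or untested is made for them only; others in the source may bear on it.

Measured compounds:
compound 1 `CCNCC(=O)Nc1cc(OC)ccc1C(=O)c1ccc(OC)c2c1OC(C)(C)C=C2`: 1980 nM
compound 2 `CCNCC(=O)Nc1cc(OC)ccc1C(=O)c1ccc2c(c1)C=CC(C)(C)O2`: 2070 nM
compound 3 `COc1ccc(C(=O)c2ccc(OC)c3c2OC(C)(C)C=C3)c(NC(=O)CN(C)C)c1`: 790 nM

In a functional assay on A2780 cells (Homo sapiens) for antiproliferative activity, read by MTT assay, with a stated time of 48 h (on this read-out lower numbers stand for stronger inhibition and higher numbers for weaker inhibition), compound 1 gives 1980 nM and compound 3 gives 790 nM. The two share a core and differ by dimethylamino in place of ethylamino on a saturated chain carbon bound to a carbonyl carbon, a change that made a 2.5-fold lower number from compound 1 to compound 3 (0.40 log units; beyond the scatter). Compound 2 gives 2070 nM in this assay, a number within the scatter of that of compound 1; the difference between the core of compound 2 and the core of compound 1 is not broken down here.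

Compound 4 `COc1ccc(C(=O)c2ccc3c(c2)C=CC(C)(C)O3)c(NC(=O)CN(C)C)c1` is not yet measured. For the measured compounds named here, it differs from compound 2 by dimethylamino in place of ethylamino on a saturated chain carbon bound to a carbonyl carbon, the same change as the one from compound 1 to compound 3, at the same place. Going by the values given here, with only one prior instance of this change, the expectation for compound 4 rests on compound 1 and compound 3 alone, where a 2.5-fold lower number from compound 1 to compound 3 (0.40 log units; beyond the scatter) was seen.

The step from compound 2 to compound 4 in this assay is expected to be a 2.5-fold lower number from compound 2 to compound 4 (0.40 log units; beyond the scatter), similar in size to the earlier one. Compound 4 is therefore estimated at 830 nM in this assay, with a range from 450 nM to 1600 nM.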

Compound 4, half-maximal inhibitory concentration: 1020 nM
For compound 4 the middle estimate is 1.2-fold (0.09 log units) below the measured one; measured number inside the range.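

On the core of compound 2, dimethylamino in place of ethylamino on a saturated chain carbon bound to a carbonyl carbon gives a 2.0-fold lower number from compound 2 to compound 4 (0.31 log units; beyond the scatter) in this assay. Set beside the earlier step, the change carries from one core to the other in the same direction and with no size difference that can be told from noise: the same change on two cores in this assay, a 2.5-fold lower number (0.40 log units; beyond the scatter) from compound 1 to compound 3 and a 2.0-fold lower number (0.31 log units; beyond the scatter) from compound 2 to compound 4, 1.2-fold (0.09 log units) apart, within the scatter of two such steps. For the compounds shown here, this rests on only two matched pairs in a single cell assay, so it shows that the change transferred between these two cores, but not that it would transfer to any other core, nor why the number falls.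

The compounds shown leave open whether the trend extends to other amines on the same chain, such as diethylamino or a primary amine. Also open, on these data alone, is whether a longer chain carrying the dimethylamino group would keep the lower number on either core.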